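The compounds below may be only part of what the source reports. "The series", "measured", "known", "first", "only" and "open" are said of these compounds alone.

Two members of the series have been measured in an assay on IMR-32 cells for displacement of a labelled ligand from corticotropin-releasing factor receptor 1 (Homo sapiens), read by scintillation counting, with a stated time of 2 h; a lower number here means a stronger inhibitor, a higher number a weaker inhibitor. Compound 1 `CCOc1ccc(-c2nc(OC)c(NC(CC)CC)nc2C)c(Cl)c1` gives 5.9 nM and stands lowest of the two numbers. Among the compounds with values here, compound 2 `CCc1nc(-c2ccc(Cl)cc2Cl)c(CC)nc1NC(C)CN(C)C` gives 489 nM in this assay, the nearest value to compound 1 and a much higher number, beyond the scatter of repeated measurements; the two structures differ in several places at once, so this pair shows only that its two values lie far apart. Compound 3 `CCC(CC)Nc1nc(C)c(-c2ccc(OC(F)F)cc2Cl)nc1OC` has not yet been measured in this assay. It differs from compound 1 in one place: difluoromethyl in place of ethyl on an oxygen on an aromatic ring. Within the data shown here, no measured pair carries this change, so the size of the step rests on judgement. Among the measured compounds shown here, the change leaves the oxygen where it is and exchanges one small group on it for another; nothing in the two numbers known points to a large shift in either direction. For compound 3 the step expected in this assay is a 1.4-fold higher number from compound 1 to compound 3 (0.13 log units; within the scatter), small and not beyond the scatter. Compound 3 is expected to give 8 nM in this assay, within 2.5 nM to 25 nM.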

Compound 3, inhibition constant: 4.6 nM
Compound 3: middle estimate off by 1.7-fold (0.24 log units), on the high side; measured number inside the range.
By their numbers in this assay, from the lowest: compounds 3 and 1 (each within the scatter of the next); then compound 2.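

In this assay, the step from ethyl to difluoromethyl on an oxygen on an aromatic ring is a 1.3-fold lower number from compound 1 to compound 3 (0.11 log units; within the scatter) and stays within the scatter, so compound 1 and compound 3 cannot be placed in any order. Within the data shown here, this is the first step that can be read at a single place, as the earlier pair differs in several places at once and showed only that its two values lie far apart. Here, ethoxy to difluoromethoxy leaves the result in the same range, but no measurement on hand bears on why the two values stand together.

On these data alone, whether this oxygen carries other groups equally well remains open, for example a longer chain such as propyl, trifluoromethyl, or a bare hydroxyl with no group on the oxygen at all. Also open, as far as these compounds go, is whether ethoxy to difluoromethoxy gives a similar step on a compound with a different chain on the amine nitrogen, such as the dimethylamino-bearing chain of compound 2.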